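Chloro in Place of Formyl on the Shared Core

The compounds below may be only part of what the source reports. "The series", "measured", "known", "first", "only" and "open" are said of these compounds alone.

Compound 1, `COc1ccc(-c2cn3ccnc3c(-c3ccc4ncn(C5CCCCC5)c4c3)n2)cc1`, gives 49.9% in a functional assay on SF-268 cells (Homo sapiens) for inhibition, read by sulforhodamine B assay, with a stated time of 48 h, tested at 10 uM; a lower number here means less inhibition, a higher number more inhibition at the concentration tested (going by the name of the read-out).
Compound 2, `O=Cc1ccc(-c2cn3ccnc3c(-c3ccc4ncn(C5CCCCC5)c4c3)n2)cc1`, gives 27.1% in this assay.
Compound 3, `Fc1ccc(-c2cn3ccnc3c(-c3ccc4ncn(C5CCCCC5)c4c3)n2)cc1`, gives 10.7% in this assay.

Compound 2 stands second highest of the three measured numbers, with both neighbours beyond the scatter: a number 22.8 percentage points lower from compound 1 to compound 2 (beyond the scatter), and a number 16.4 percentage points lower from compound 2 to compound 3 (beyond the scatter). Compound 4, `Clc1ccc(-c2cn3ccnc3c(-c3ccc4ncn(C5CCCCC5)c4c3)n2)cc1`, differs from compound 2 by chloro in place of formyl on an aromatic carbon. Going by the values given here, the one measured step that bears on this change is the exchange of formyl for fluoro, which was a number 16.4 percentage points lower from compound 2 to compound 3 (beyond the scatter); chloro is likewise a halogen at the same place, and no other step involves it. A modest step downward in this assay is therefore expected. Compound 4 is estimated to give about 14%, in a range from 0% to 34%. For compound 4 this estimate means an expected step of a number 13.1 percentage points lower from compound 2 to compound 4 (beyond the scatter).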

Compound 4, a percentage reported as inhibition, at one concentration (the size of the read-out at that concentration, not a potency): 4.83%
For compound 4 the middle estimate is 9.2 percentage points above the measured one; measured number inside the range.
By their numbers in this assay, from the lowest: compounds 4 and 3 (each within the scatter of the next); then compound 2; then compound 1.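

In this assay, chloro in place of formyl gives a number 22.3 percentage points lower from compound 2 to compound 4 (beyond the scatter), whereas chloro in place of fluoro gives a number 5.9 percentage points lower from compound 3 to compound 4 (within the scatter), so the two halogens at this position cannot be told apart. Both halogen compounds stand below the formyl compound, and the change from methoxy to chloro gives a number 45.1 percentage points lower from compound 1 to compound 4 (beyond the scatter), a large step of the same kind as that from methoxy to fluoro. No evidence shown here accounts for these steps.

Going by these compounds, what an amine, a carboxylic acid or a longer chain would give at this place remains open.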